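Swapping a hydroxymethyl for a dimethylsulfamoyl on the aryl ring

A few compounds are considered here, and "the series" means these few. Any claim that something is new, unique, unknown or untested is made for them only; others in the source may bear on it.

Among the compounds with values here, the three compounds measured so far share the same acid-bearing core joined through an alkyne to a second aromatic ring, and differ in what decorates that second ring. Compound 1 `CCCS(=O)(=O)c1cccc(C#Cc2cc(F)ccc2OCC(=O)O)c1` carries a propylsulfonyl group and gives 65 nM in an assay on CHO cells for displacement of a labelled ligand from prostaglandin D2 receptor 2 (Homo sapiens), read by scintillation counting; a lower number here means a stronger inhibitor, a higher number a weaker inhibitor. Compound 3 `CS(=O)(=O)c1cncc(C#Cc2cc(Cl)ccc2OCC(=O)O)c1` carries a methylsulfonyl group and gives 60 nM in this assay. Compound 2 `O=C(O)COc1ccc(Cl)cc1C#Cc1cc(CO)ccc1F` carries a hydroxymethyl group and gives 73 nM in this assay; its number is the highest of the three, but it lies within the scatter of both compound 1 and compound 3, so the three cannot be separated on these data.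

Compound 4 `CN(C)S(=O)(=O)c1ccc(F)c(C#Cc2cc(Cl)ccc2OCC(=O)O)c1` has not yet been measured. Relative to compound 2 it differs in one place: dimethylsulfamoyl in place of hydroxymethyl on an aromatic carbon

Within the data shown here, no step between two measured compounds covers this exact change, so the expectation rests on the other two compounds. Compound 1 and compound 3, each bearing a sulfonyl-type group on the same ring, both give numbers close to that of compound 2, so the author expects the step from compound 2 to compound 4 to be small, if anything toward a lower number, and likely within the scatter: a 1.3-fold lower number from compound 2 to compound 4 (0.12 log units; within the scatter). Compound 4 is therefore estimated at 55 nM, with a range from 25 nM to 120 nM.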

Compound 4, inhibition constant: 3.1 nM
The estimate for compound 4 lay 18-fold (1.25 log units) above the measured number; the whole stated range lies above it.
By their numbers in this assay, from the lowest: compound 4; then compounds 3, 1 and 2 (each within the scatter of the next).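

Putting dimethylsulfamoyl in place of hydroxymethyl on this aromatic carbon, meta to a large group and para to a fluoro group, gives a 24-fold lower number from compound 2 to compound 4 (1.37 log units; beyond the scatter) in this assay, so what sits at this position can move the number well beyond the scatter, which the earlier three values, all within the scatter of one another, gave no sign of. The change replaces a group of 2 heavy atoms with 1 hydrogen-bond donor and 1 hydrogen-bond acceptor by one of 6 heavy atoms with 0 hydrogen-bond donors and 2 hydrogen-bond acceptors, and this single step cannot show which of these differences matters. No measurement offered here accounts for the size of the step.

On these data alone, compound 1 and compound 3 differ from compound 4 in more than one place, so they do not show whether the sulfamoyl nitrogen matters, and it remains open whether a methylsulfonyl group at this same place on the core of compound 4 would give a similar number. Also open, as far as these compounds go, is how an unsubstituted sulfamoyl group, or longer chains on its nitrogen, would compare with dimethylsulfamoyl.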